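This account rests on a few compounds, and the source may have more. Where it says the series, first, only, none or still open, it means among the compounds named here.

Of the compounds shown here, three on a shared core have been measured in a functional assay on MCF7 cells (Homo sapiens) for antiproliferative activity, read by MTT assay, with a stated time of 72 h; on this read-out higher numbers stand for weaker inhibition and lower numbers for stronger inhibition. Compound 1 `COc1cc(-n2cnc3ccc(-c4ccc(C(F)(F)F)cc4)cc32)cc(OC)c1OC` gives 760 nM, compound 2 `COc1cc(-n2cnc3ccc(-c4cccc(N)c4)cc32)cc(OC)c1OC` gives 180 nM, and compound 3 `COc1cc(-n2cnc3ccc(-c4cccc([N+](=O)[O-])c4)cc32)cc(OC)c1OC` gives 4560 nM. Compound 3 therefore has the highest number of the three and is the weakest inhibitor of the set.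

The next compound, compound 4 `COc1ccc(-c2ccc3ncn(-c4cc(OC)c(OC)c(OC)c4)c3c2)cc1`, changes only the group on the aromatic carbon: 4-methoxyphenyl in place of 3-nitrophenyl on an aromatic carbon. In words, 4-methoxyphenyl stands in place of 3-nitrophenyl. This group has not yet been measured in the series, so the expectation rests on the steps that involve compound 3.

The data show a 6.0-fold higher number from compound 1 to compound 3 (0.78 log units; beyond the scatter), a modest step, and a 25-fold higher number from compound 2 to compound 3 (1.40 log units; beyond the scatter), a large one. Read in reverse, both measured replacements of 3-nitrophenyl gave a lower number. The remaining step, a 4.2-fold lower number from compound 1 to compound 2 (0.63 log units; beyond the scatter), shows that the replacing group matters, so the size of the drop stays uncertain. The closest guide is compound 1 at 760 nM, which also carries a group named at the 4-position of the phenyl ring.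

A modest step towards stronger inhibition is therefore expected in this assay, and the estimated change is a 7.6-fold lower number from compound 3 to compound 4 (0.88 log units; beyond the scatter). For compound 4 the expected value is 600 nM, with an estimated range from 170 nM to 2100 nM.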

Compound 4, half-maximal inhibitory concentration: 210 nM
Estimate against measurement, compound 4: 2.9-fold (0.46 log units) above; the range from low to high includes it.
By their numbers in this assay, from the lowest: compounds 2 and 4 (each within the scatter of the next); then compound 1; then compound 3.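

In this assay, 4-methoxyphenyl in place of 3-nitrophenyl gives a 22-fold lower number from compound 3 to compound 4 (1.34 log units; beyond the scatter), so this position now has a second replacement of 3-nitrophenyl with a large step towards stronger inhibition, alongside 3-aminophenyl. The new group cannot be told apart from 3-aminophenyl, with a 1.2-fold higher number from compound 2 to compound 4 (0.07 log units; within the scatter), which shows that two phenyl groups differing in both substituent and ring position can give values within the scatter of each other at this carbon. The earlier compounds shown here held no pair that differed only in the substituent at the same ring position, and methoxy in place of trifluoromethyl now supplies one, with a 3.6-fold lower number from compound 1 to compound 4 (0.56 log units; beyond the scatter), showing that the identity of that substituent matters here even with its ring position unchanged.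

The compounds shown do not separate the effect of the substituent from that of its ring position, a question that 3-methoxyphenyl and 4-aminophenyl would address directly, while 4-ethoxyphenyl would test a longer chain on the oxygen. Nothing available here explains any of these steps.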